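The source may report more compounds than this note shows. Statements on the series, on what has been measured and on what is new or still open speak of the compounds shown alone.

Measured so far:
- compound 1, `Cc1cc(C)cc(NC(=O)N(Cc2ccc(C(=O)NC[C@@H](O)C(=O)O)cc2)[C@H]2CC[C@H](C(C)(C)C)CC2)c1` — 220 nM
- compound 2, `O=C(NC[C@@H](O)C(=O)O)c1ccc(CN(C(=O)Nc2cccc(Br)c2)c2ccc(C3CCCCC3)cc2)cc1` — 216 nM

Two compounds of the series carry numbers. In an in vitro assay on BHK cells for binding affinity to gastric inhibitory polypeptide receptor (Homo sapiens) (on this read-out lower numbers stand for stronger inhibition and higher numbers for weaker inhibition), compound 1 gives 220 nM; compound 2 gives 216 nM. Compound 1 stands at one end of these two values, with compound 2 sitting within the scatter of it, so the two are not told apart by this assay. The two compounds differ in several places at once, so nothing about any single change can be drawn from them.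

Compound 3, `Cc1cc(NC(=O)N(Cc2ccc(C(=O)NC[C@@H](O)C(=O)O)cc2)[C@H]2CC[C@H](C(C)(C)C)CC2)cc(C(F)(F)F)c1`, is not yet measured. It follows from compound 1 by a single change: trifluoromethyl in place of methyl on an aromatic carbon. Among the measured compounds shown here, no pair of measured compounds shows this kind of exchange, so the size of the step has to be guessed. Given that compound 1 gives 220 nM, the expectation is a step from compound 1 to compound 3 of a 1.5-fold lower number from compound 1 to compound 3 (0.17 log units; within the scatter), small and of uncertain direction, at most just beyond the scatter. For compound 3 the estimated value in this assay is 150 nM, with a range from 50 nM to 450 nM.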

Compound 3, half-maximal inhibitory concentration: 98 nM
Compound 3: the middle estimate sits 1.5-fold (0.18 log units) above what was measured; low and high end bracket the measured number.
By their numbers in this assay, from the lowest: compound 3; then compounds 2 and 1 (each within the scatter of the next).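

In this assay, the 3,5-dimethylphenyl of compound 1 responds to a single exchange on an aromatic carbon: trifluoromethyl in place of methyl gives a 2.2-fold lower number from compound 1 to compound 3 (0.35 log units; beyond the scatter). Among the compounds shown here, this is the only one-place step so far, and it shows that the larger group, with 4 heavy atoms against 1, goes with a lower number at this position, meta to a methyl group, while the rest of the compound stays the same. Nothing at hand accounts for the step, which stands here as an observation only.

On these data alone, it remains open whether a chlorine, a nitrile or an ethyl group on the same aromatic carbon would move the number in the same direction, or whether the effect is particular to trifluoromethyl. Also open, as far as these compounds go, is whether putting a second trifluoromethyl in place of the remaining methyl group would lower the number further, and whether the exchange would give a step of similar size on a different core.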